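The source may hold more compounds than are shown below. What is called first, only, known or untested is meant among the compounds shown, and "the series" means these compounds.

Compound 2 `CC(C)=Cc1nn(CCC(C)C)c(=O)c(C2=NS(=O)(=O)c3cc(NS(C)(=O)=O)ccc3N2)c1O`: in an ADME assay on Huh-7 cells (Homo sapiens) for cytotoxicity, with a stated time of 72 h (a lower number here means that less compound is tolerated, a higher number that more compound is tolerated), compound 2 gives > 1000 nM, which is a limit of the assay, not a number.
Compound 3 `CCC(C)CCn1nc(-c2cccs2)c(O)c(C2=NS(=O)(=O)c3cc(NS(C)(=O)=O)ccc3N2)c1=O`: in this assay compound 3 gives > 1000 nM, again a limit of the assay.
Compound 1 `CC(C)CCn1nc(-c2cccs2)c(O)c(C2=NS(=O)(=O)c3cc(N(C(C)C)S(C)(=O)=O)ccc3N2)c1=O`: in this assay compound 1 gives "not determined" (no result reported), so no result is available for it.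

Compound 3 thus stands at the limit rather than at a measured number, and compound 2 sits at the same limit (the limit of > 1000 nM in this assay, at which 2 of the 3 values shown sit); compound 1 adds nothing here. Compound 4 `CS(=O)(=O)Nc1ccc2c(c1)S(=O)(=O)N=C(c1c(O)c(-c3cccs3)nn(CCC3CCCCC3)c1=O)N2` differs from compound 3 in one place: cyclohexyl in place of sec-butyl on a saturated chain carbon, two bonds along the chain from an aromatic nitrogen. Within the data shown here, no step between measured compounds is available, so the size of this change in this assay cannot be read from the series; with both recorded values at the limit, no shift beyond the scatter is expected, and another limit is the likeliest outcome. The estimate for compound 4 in this assay is 1500 nM, range 700 nM to 5000 nM, an expected step that the limit leaves unreadable from compound 3 to compound 4.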

Compound 4, half-maximal cytotoxic concentration: > 17000 nM
Compound 4: only a limit was reported (the forecaster's own chance of this, stated with the estimate: 80%); at least 11-fold (1.05 log units) between middle value and limit.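

In this assay compound 4 gives > 17000 nM, a limit. Among these compounds, compound 3 gives > 1000 nM, also a limit, so no step from compound 3 to compound 4 can be read. The compounds shown leave open whether cyclohexyl in place of sec-butyl changes the half-maximal cytotoxic concentration at all.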